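Swapping a phenoxy group for bromine on the shared core

The source may report more compounds than this note shows. Statements on the series, on what has been measured and on what is new or still open speak of the compounds shown alone.

Measured compounds:
compound 1 `O=C(Nc1nn[nH]n1)c1cccc(Oc2ccccc2)n1` gives 0%
compound 2 `CCCCc1ccnc(C(=O)Nc2nn[nH]n2)c1` gives 54%
compound 3 `Cc1ccc(C(=O)Nc2nn[nH]n2)nc1C` gives 42%

In a functional assay on the whole organism for inhibition, with Rattus norvegicus as the target, at a dose of 10 mg/kg by the oral route (a lower number here means a weaker effect, a higher number a stronger effect of the compound at the dose given), compound 1 gives 0%, the lowest of the three numbers; compound 3 gives 42% and compound 2 gives 54%, and both of these stand higher than compound 1, both gaps beyond the scatter. Compound 4 `O=C(Nc1nn[nH]n1)c1cccc(Br)n1` has not yet been measured. It differs from compound 1 in one place: bromo in place of phenoxy on an aromatic carbon, on an aromatic carbon of a six-membered aromatic ring with one nitrogen, next to the ring nitrogen. Within the data shown here, no step between two measured compounds resembles this change, so the direction must be guessed. Because compound 1 sits at 0%, a step upward of moderate size, a number 30 percentage points higher from compound 1 to compound 4 (beyond the scatter), is expected. Compound 4 is estimated at 30%, in the range 5% to 60%.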

Compound 4, a percentage reported as inhibition, in the whole organism at one dose (the size of the read-out at that dose, not a potency): 48%
Compound 4: middle estimate off by 18 percentage points, on the low side; low and high end bracket the measured number.
By their numbers in this assay, from the lowest: compound 1; then compounds 3, 4 and 2 (each within the scatter of the next, the first and the last beyond it).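

In this assay, bromo in place of phenoxy on the aromatic carbon next to the ring nitrogen gives a number 48 percentage points higher from compound 1 to compound 4 (beyond the scatter) on the shared core. This single change shows that the group at this position can decide between no measurable effect at this dose and a clear one. No measurement here explains the step. On these data alone, whether an amine, a methoxy group or chloro at this position would match bromo remains open. So does whether a phenyl group joined directly to the ring, without the oxygen of phenoxy, would also give no effect.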